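Benzyloxy for amino on a carbonyl carbon: compound 4

This account rests on a few compounds, and the source may have more. Where it says the series, first, only, none or still open, it means among the compounds named here.

In a functional assay on the whole organism (Tail, strain ICR) with Mus musculus as the target, in the tail flick test, with a stated time of 120 min, at a dose of 25 umol/kg by the oral route (a lower number here means a weaker effect, a higher number a stronger effect of the compound at the dose given), compound 1 `O=C(CN(c1nc(Cl)nc2[nH]cnc12)C1CC1)N[C@@H](CC(=O)OCc1ccccc1)C(=O)OCc1ccccc1` gives 12.1%, compound 3 `NC(=O)C[C@H](NC(=O)CN(c1nc(Cl)nc2[nH]cnc12)C1CC1)C(=O)OCc1ccccc1` gives 15.1%, and compound 2 `NC(=O)CC[C@H](NC(=O)CN(c1ncnc2c1ncn2C1CCCCO1)C1CC1)C(=O)OCc1ccccc1` gives 22.3%. Compound 2 stands at the top of the three numbers, yet only its gap to compound 1 lies beyond the scatter; its gap to compound 3 does not. Compound 4 `O=C(CN(c1ncnc2c1ncn2C1CCCCO1)C1CC1)N[C@@H](CCC(=O)OCc1ccccc1)C(=O)OCc1ccccc1` differs from compound 2 by benzyloxy in place of amino on a carbonyl carbon. Among the compounds with values here, the single measured step that bears on this change runs the opposite way, a number 3 percentage points higher from compound 1 to compound 3 (within the scatter), and no shift beyond the scatter follows from it. The number for compound 4 in this assay is therefore expected to stay close to that of compound 2, the expected step being a number 3.3 percentage points lower from compound 2 to compound 4 (within the scatter). Compound 4 is estimated at 19%, within a range from 8% to 30%.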

Compound 4, a percentage reported as activity, at one dose (the size of the read-out at that dose, not a potency): 20.7%
Estimate against measurement, compound 4: 1.7 percentage points below, and the stated range covers the measured number.
By their numbers in this assay, from the lowest: compounds 1, 3, 4 and 2 (each within the scatter of the next, the first and the last beyond it).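

In this assay the change now has a second reading on a different core, with a number 1.6 percentage points lower from compound 2 to compound 4 (within the scatter). This position carries amino or benzyloxy, with its six-membered aromatic ring of carbon only, and no shift beyond the scatter appears on either core. The two steps also agree with each other: the same change on two cores in this assay, a number 3 percentage points higher (within the scatter) from compound 1 to compound 3 and a number 1.6 percentage points higher (within the scatter) from compound 4 to compound 2, 1.4 percentage points apart, within the scatter of two such steps

Open, on these data alone, is what a carboxylic acid or a dimethylamino group on this carbonyl carbon would give. As far as these compounds go, a longer chain between this carbonyl carbon and the rest of the molecule also remains open.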